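The compounds below may be only part of what the source reports. "The series", "measured", "known", "first", "only" and "open" are said of these compounds alone.

Working notes on the series.

Compound 1 `CCC(C)(CC)/N=C(\NC#N)Nc1ccncc1` and compound 2 `CCC(CC)(CC)/N=C(\NC#N)Nc1ccncc1` share one core and are both measured in a functional assay on the whole organism (blood, strain Wistar-Okamoto) with Rattus norvegicus as the target, with a stated time of 5 days; on this read-out lower numbers stand for an effect already at smaller amounts and higher numbers for an effect only at larger amounts of compound. Compound 1 gives 0.5 mg/kg. Compound 2 gives 2.5 mg/kg. The step of a 5.0-fold higher number from compound 1 to compound 2 (0.70 log units; beyond the scatter) comes from the change (methyl in place of hydrogen on a saturated chain carbon, two bonds along the chain from a double-bonded nitrogen).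

Compound 3 `CC(C)(C)N/C(=N\O)Nc1cccnc1` sits on a different core; the difference between the two cores is not broken down here. In this assay compound 3 reaches only a limit, > 35 mg/kg, and that is the limit (the limit of > 35 mg/kg in this assay, at which 1 of the 3 values shown sits).

Compound 4 `CCC(C)(C)N/C(=N\O)Nc1cccnc1` is not yet measured. It differs from compound 3 by methyl in place of hydrogen on a saturated chain carbon, two bonds along the chain from an amine nitrogen. This is the same kind of change as from compound 1 to compound 2, but not the same: in the measured pair the methyl enters two bonds along the chain from a double-bonded nitrogen, whereas here it enters two bonds along the chain from an amine nitrogen.

The expectation for compound 4 rests on the measured pair, where the step of a 5.0-fold higher number from compound 1 to compound 2 (0.70 log units; beyond the scatter) went toward higher numbers, and on compound 3 already standing at the limit (the limit of > 35 mg/kg in this assay, at which 1 of the 3 values shown sits). For compound 4 the estimated step is a step that the limit leaves unreadable from compound 3 to compound 4. Compound 4 is therefore expected to give about 60 mg/kg, most likely again only a limit, within roughly 25 mg/kg to 150 mg/kg.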

Compound 4, minimum effective dose: > 20 mg/kg
Compound 4: a limit, no number; the forecaster's own chance of this, stated with the estimate: 80%; the middle value is on the limit's open side.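

In this assay compound 3 reaches only a limit: the limit of > 35 mg/kg in this assay, at which 1 of the 4 values shown sits. Among the compounds shown here, compound 4 also reaches only a limit, so no step from compound 3 to compound 4 can be read: the limit of > 20 mg/kg in this assay, at which 1 of the 4 values shown sits. The compounds shown leave open whether methyl in place of hydrogen at this place changes the minimum effective dose on the core of compound 3.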